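The compounds below may be only part of what the source reports. "The series", "measured", "known", "first", "only" and "open" are said of these compounds alone.

Measured so far:
compound 1 `OCCOCn1cnc2c(O)ncnc21` — > 100 ug/mL
compound 2 `Nc1nc2c(nc(Br)n2COCCO)c(=O)[nH]1` — 340 ug/mL

In a functional assay (Oryctolagus cuniculus) for inhibition (a higher number here means a weaker inhibitor, a lower number a stronger inhibitor), compound 1 gives only the limit > 100 ug/mL, not a number. Among the measured compounds shown here, compound 2 gives the one plain number in this assay, 340 ug/mL; of the two values shown, one sits at the limit of > 100 ug/mL in this assay, at which 1 of the 2 values shown sits. Compound 3 `Nc1nc2c(nc(O)n2COCCO)c(=O)[nH]1` is not yet measured and differs from compound 2 by hydroxy in place of bromo on an aromatic carbon. For the measured compounds named here, no step between measured compounds is at hand. The expected step in this assay from compound 2 to compound 3 is a 1.1-fold lower number from compound 2 to compound 3 (0.05 log units; within the scatter), none beyond the scatter. Compound 3 is estimated at 300 ug/mL, in the range 100 ug/mL to 1000 ug/mL.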

Compound 3, concentration for 50% inhibition: 48 ug/mL
For compound 3 the middle estimate is 6.3-fold (0.80 log units) above the measured one, and the stated range ends above it.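

In this assay, the position on the five-membered aromatic ring, between two ring nitrogen atoms, responds to the group it carries: hydroxy in place of bromo gives a 7.1-fold lower number from compound 2 to compound 3 (0.85 log units; beyond the scatter). Among the compounds shown here, this is the first readable step, and it shows that a change at this position alone, with the (2-hydroxyethoxy)methyl group kept, moves the read-out beyond the scatter.

On these data alone, whether the lower number reflects hydroxy itself or the loss of bromo stays open, with no amine or methyl at this position for comparison. Compound 1 carries a limit, not a number, and gives no step: the limit of > 100 ug/mL in this assay, at which 1 of the 3 values shown sits.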